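Swapping amino for chloro on a fused dichloropurine-like core

The source may hold more compounds than are shown below. What is called first, only, known or untested is meant among the compounds shown, and "the series" means these compounds.

Compound 1 `Nc1nc(Cl)c2ncn(Cc3ccccc3CCl)c2n1` carries an amino group on its shared core, yet in a functional assay on RXF 393 cells (Homo sapiens) for cytotoxicity, read by sulforhodamine B assay, with a stated time of 48 h (a higher number here means a weaker inhibitor of growth, a lower number a stronger inhibitor of growth), compound 1 gives "not determined" (no result reported). Going by the values given here, the only number available comes from compound 2 `ClCc1cccc(Cn2cnc3nc(Cl)nc(Cl)c32)c1`, a close relative with a chloro group in the same place: in this assay compound 2 gives 2630 nM. Compound 1 therefore stands nowhere on the numbers shown; no value anchors it.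

The step to compound 3 `ClCc1ccccc1Cn1cnc2c(Cl)nc(Cl)nc21` is chloro in place of amino on an aromatic carbon. Among the compounds with values here, since compound 1 has no measurement, no step between measured compounds can be traced, and nothing in the data says in which direction this change would move the concentration for total growth inhibition. A step beyond the usual scatter cannot be expected from what is at hand, so the estimate leans on compound 2 because compound 2 gives 2630 nM and shares the chloro group that enters in compound 3.

Compound 3 is expected to reach about 3000 nM in this assay, with a likely range from 900 nM to 10000 nM.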

Compound 3, concentration for total growth inhibition: 490 nM
For compound 3 the middle estimate is 6.1-fold (0.79 log units) above the measured one; the measured number lies below the stated range.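

In this assay, going by these compounds alone, compound 1 gives "not determined" (no result reported) while compound 3 gives 490 nM and so no step between the two can be read. The compounds shown leave open how chloro in place of amino on the shared core moves the concentration for total growth inhibition. Nothing at hand bears on the result for compound 3.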